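Trifluoromethylsulfonyl analogue in a series without measurable cytotoxicity

A few compounds are considered here, and "the series" means these few. Any claim that something is new, unique, unknown or untested is made for them only; others in the source may bear on it.

Compound 1, `Cc1c(-c2ccc(Cc3ccc(C(C)(C)C)cc3)cc2)[nH]c2cccc(F)c2c1=O`, gives > 5000 nM in an ADME assay on Huh7.5.1 cells (Homo sapiens) for cytotoxicity, read by WST assay, with a stated time of 48 h (a lower number here means that less compound is tolerated, a higher number that more compound is tolerated), which is a limit of the assay and not a number.
Compound 2, `Cc1c(-c2ccc(Cc3ccc(OCC(F)(F)F)cc3)cc2)[nH]c2cccc(F)c2c1=O`, gives > 5000 nM in this assay, again a limit.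
Compound 3, `Cc1c(-c2ccc(Cc3ccc(C(O)C(F)(F)F)cc3)cc2)[nH]c2cccc(F)c2c1=O`, gives > 10000 nM in this assay, also a limit.

Compound 3 thus stands only at a limit; the two other values shown are limits as well, as the limit of > 10000 nM in this assay, at which 1 of the 3 values shown sits, and the limit of > 5000 nM in this assay, at which 2 of the 3 values shown sit, record. Compound 4, `Cc1c(-c2ccc(Cc3ccc(S(=O)(=O)C(F)(F)F)cc3)cc2)[nH]c2cccc(F)c2c1=O`, differs from compound 3 by (trifluoromethyl)sulfonyl in place of 2,2,2-trifluoro-1-hydroxyethyl on an aromatic carbon. Going by the values given here, the steps that bear on this change are a step that the two limits leave unreadable from compound 1 to compound 3 and a step that the two limits leave unreadable from compound 2 to compound 3, neither of which yields a readable size. No readable step of any direction is therefore available, and the step expected is a number no higher from compound 3 to compound 4 (the limit leaves the size open), most probably ending at a limit once more. Compound 4 is estimated at 10000 nM, within a range from 5000 nM to 20000 nM.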

Compound 4, half-maximal cytotoxic concentration: > 2500 nM
Compound 4 was reported as a limit; the forecaster's own chance of this, stated with the estimate: 85%; the middle value lies beyond the limit too.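

Compound 4, like compound 1, compound 2 and compound 3, stands only at a limit, so none of the steps among them can be read. The compounds shown leave open what concentration of any of them would reach the half-maximal cytotoxic level in this assay.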